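The source may report more compounds than this note shows. Statements on the series, on what has been measured and on what is new or still open speak of the compounds shown alone.

Measured compounds:
- compound 1, `COc1ccc(/C=C2\CCC/C(=C\c3ccccc3[N+](=O)[O-])C2=O)cc1`, 11.2 ug/mL
- compound 2, `COc1ccc(/C=C2\CCC/C(=C\c3cccc([N+](=O)[O-])c3)C2=O)cc1`, 5.71 ug/mL
- compound 3, `COc1cc(/C=C2\CCC/C(=C\c3cccc([N+](=O)[O-])c3)C2=O)cc(Br)c1OC`, 4.72 ug/mL

All three were tested in a functional assay on MCF7 cells (Homo sapiens) for cytotoxicity, read by MTT assay; on this read-out higher numbers stand for weaker inhibition and lower numbers for stronger inhibition. Among these three numbers compound 2, with 5.71 ug/mL, stands second highest. Its nearest neighbour is compound 3, whose 4.72 ug/mL lies within the scatter of compound 2; the furthest is compound 1, whose 11.2 ug/mL also stays within the scatter. Among the compounds with values here, the three values therefore cannot be ordered against each other, and no compound can be called stronger or weaker than another on this evidence.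

Compound 4, `O=C1/C(=C/c2cccc(Cl)c2)CCC/C1=C\c1cccc([N+](=O)[O-])c1`, has not yet been measured in this assay. It differs from compound 2 in one place: 3-chlorophenyl in place of 4-methoxyphenyl on a double-bonded chain carbon bound to a double-bonded ring carbon. Within the data shown here, no pair of measured compounds differs in exactly this way, so the size of this step has to be estimated rather than read from the data. Given that the three measured numbers all sit close together, the step from compound 2 to compound 4 is expected to be small, a 1.1-fold lower number from compound 2 to compound 4 (0.06 log units; within the scatter), with no clear direction beyond the scatter. Compound 4 is accordingly expected to give about 5 ug/mL in this assay, within a range from 2 ug/mL to 12 ug/mL.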

Compound 4, half-maximal inhibitory concentration: 5.15 ug/mL
Compound 4: the middle estimate sits 1.0-fold (0.01 log units) below what was measured, within the range that was stated.
By their numbers in this assay, from the lowest: compounds 3, 4, 2 and 1 (each within the scatter of the next, the first and the last beyond it).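

In this assay, this position now has a step that can be read directly: 3-chlorophenyl in place of 4-methoxyphenyl on a double-bonded chain carbon bound to a double-bonded ring carbon gives a 1.1-fold lower number from compound 2 to compound 4 (0.04 log units; within the scatter). The earlier compounds shown here offered no pair differing in one place, so they could say nothing about this position on its own; this pair shows that exchanging one substituted phenyl for another, with a group of 8 heavy atoms and 1 hydrogen-bond acceptor giving way to one of 7 heavy atoms and no hydrogen-bond acceptor, leaves the number within the scatter. Nothing measured here on these compounds speaks to why the two numbers stay so close, so the result stands as an observation on this single pair.

What the compounds shown leave open is whether this position stays as undemanding once the phenyl ring carries an amine or a carboxylic acid, or gives way to a longer chain. A single pair also cannot tell whether the same exchange would read the same way on the core of compound 1.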